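Pyridin-4-yl for pyridin-3-yl: notes on compound 4

The compounds below may be only part of what the source reports. "The series", "measured", "known", "first", "only" and "open" are said of these compounds alone.

- compound 1 `O=C1/C(=C/c2cccnc2)CN(S(=O)(=O)c2ccc(Cl)cc2)C/C1=C\c1ccccc1C(F)(F)F` gives 3440 nM
- compound 2 `N#Cc1ccc(S(=O)(=O)N2C/C(=C\c3cccnc3)C(=O)/C(=C/c3ccccc3C(F)(F)F)C2)cc1` gives 6150 nM
- compound 3 `CC(=O)Nc1ccc(S(=O)(=O)N2C/C(=C\c3cccnc3)C(=O)/C(=C/c3ccccc3C(F)(F)F)C2)cc1` gives 5380 nM

All three values come from a functional assay on QGY-7703 cells (Homo sapiens) for cytotoxicity, read by MTT assay, with a stated time of 24 h (on this read-out higher numbers stand for weaker inhibition and lower numbers for stronger inhibition), and lie within the scatter of one another, so compound 1 stands level with the other two on these numbers. The next compound to be read is compound 4 `O=C1/C(=C/c2ccncc2)CN(S(=O)(=O)c2ccc(Cl)cc2)C/C1=C\c1ccccc1C(F)(F)F`, which keeps the rest of compound 1 and alters one place. The difference is pyridin-4-yl in place of pyridin-3-yl on a double-bonded chain carbon bound to a double-bonded ring carbon, in words pyridin-4-yl in place of pyridin-3-yl on a double-bonded chain carbon bound to a double-bonded ring carbon.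

Within the data shown here, no measured step touches that place. All three exchange chloro, cyano and acetamido on an aromatic carbon, and they bear on the question only indirectly. The steps are a 1.8-fold higher number from compound 1 to compound 2 (0.25 log units; within the scatter) and a 1.6-fold higher number from compound 1 to compound 3 (0.19 log units; within the scatter) and a 1.1-fold lower number from compound 2 to compound 3 (0.06 log units; within the scatter), each within the scatter. Among the measured compounds shown here, no pair differs at the pyridinyl group, so no direction can be derived, and no step beyond the scatter is expected in this assay. The estimated step is a 1.0-fold higher number from compound 1 to compound 4 (0.02 log units; within the scatter) and the range is kept wide. Compound 4 is expected at 3600 nM, with an estimated range of 1700 nM to 7500 nM.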

Compound 4, half-maximal inhibitory concentration: 12700 nM
Compound 4: the middle estimate sits 3.5-fold (0.55 log units) below what was measured; the measured number lies above the stated range.
By their numbers in this assay, from the lowest: compounds 1, 3 and 2 (each within the scatter of the next); then compound 4.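

In this assay, the exchange at this place, on a double-bonded chain carbon bound to a double-bonded ring carbon, gives a 3.7-fold higher number from compound 1 to compound 4 (0.57 log units; beyond the scatter), the only step shown that lies beyond the scatter; the exchanges among chloro, cyano and acetamido on an aromatic carbon all stay within it. Pyridin-3-yl and pyridin-4-yl match in heavy atoms, ring size, hydrogen-bond donors and acceptors and net charge, and differ only in how the same atoms are joined, so the read-out at this place responds to a change that leaves all those counts the same. No measurement at hand gives a reason for the step.

The compounds shown leave open whether phenyl or pyridin-2-yl at this place would read with compound 1 or with compound 4, and whether the same exchange gives a step of similar size with cyano or acetamido in place of chloro on the aromatic carbon. They also leave open how this assay responds to an amine or a carboxylic acid on the pyridine ring.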